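The source may report more compounds than this note shows. Statements on the series, on what has been measured and on what is new or still open speak of the compounds shown alone.

Two compounds share one core and differ only in the aryl group attached to the five-membered ring. In a functional assay on BJAB cells (Homo sapiens) for antiproliferative activity, with a stated time of 4 days (a lower number here means that less compound is needed, a higher number that more compound is needed for the effect), compound 1 `Cc1nn(-c2nc(-c3ccc(Cl)c(Cl)c3)c(SC(C)C)s2)c(C(=O)O)c1-c1cccc(Cl)c1C` gives 5100 nM, while compound 2 `COc1ccccc1-c1c(C)nn(-c2nc(-c3ccc(Cl)c(Cl)c3)c(SC(C)C)s2)c1C(=O)O` gives 14700 nM, the highest of the two numbers. Among the measured compounds shown here, the single measured step is a 2.9-fold higher number from compound 1 to compound 2 (0.46 log units; beyond the scatter), where 2-methoxyphenyl replaced 3-chloro-2-methylphenyl.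

Compound 3 `Cc1nn(-c2nc(-c3ccc(Cl)c(Cl)c3)c(SC(C)C)s2)c(C(=O)O)c1-c1cccc(Cl)c1` makes the change (3-chlorophenyl in place of 2-methoxyphenyl on an aromatic carbon). This brings back a chlorine-bearing ring, the reverse direction of that step, so a lower number of similar size is expected in this assay. Compound 3 is therefore estimated at 6000 nM, with a range from 2500 nM to 15000 nM. The expected step is a 2.5-fold lower number from compound 2 to compound 3 (0.39 log units; beyond the scatter).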

Compound 3, half-maximal effective concentration: 13600 nM
Estimate against measurement, compound 3: 2.3-fold (0.36 log units) below; the measured number falls inside the stated range.
By their numbers in this assay, from the lowest: compound 1; then compounds 3 and 2 (each within the scatter of the next).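

Putting 3-chlorophenyl in place of 2-methoxyphenyl gives no readable difference in this assay (a 1.1-fold lower number from compound 2 to compound 3 (0.03 log units; within the scatter)). A chlorine on this aryl ring is thus not enough to match compound 1, and the methyl of its 3-chloro-2-methylphenyl group matters in this series: with hydrogen there, the number is higher (a 2.7-fold higher number from compound 1 to compound 3 (0.43 log units; beyond the scatter)). No measured evidence explains this.

On these data alone, whether a 2-methylphenyl ring without the chlorine would match compound 1 stays open. So does the effect of an ethyl group in place of that methyl, or of an amine on this ring.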